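The source may report more compounds than this note shows. Statements on the series, on what has been measured and on what is new or still open speak of the compounds shown alone.

In a functional assay on KB cells (Homo sapiens) for antiproliferative activity, read by sulforhodamine B assay, with a stated time of 3 days (on this read-out higher numbers stand for an effect only at larger amounts of compound and lower numbers for an effect already at smaller amounts), compound 3 `CCC1=C(O)c2c(oc(-c3ccc(C)cc3C)cc2=O)C(CC)(CC)C1=O` gives 41.2 uM, the highest of the two numbers recorded here. Compound 1 `CCC1=C(O)c2c(oc(-c3cccc(OC)c3)cc2=O)C(CC)(CC)C1=O` gives 13.3 uM, and the change from 3-methoxyphenyl to 2,4-dimethylphenyl brought a 3.1-fold higher number from compound 1 to compound 3 (0.49 log units; beyond the scatter). Compound 2 `CCC1=C(O)c2c(oc(-c3cccc(F)c3)cc2=O)C(CC)(CC)C1=O` reaches only a limit, > 56.2 uM, namely (the limit of > 56.2 uM in this assay, at which 1 of the 3 values shown sits). From compound 2 the step was an at least 1.3-fold lower number from compound 2 to compound 3 (0.13 log units; that floor lies within the scatter), so those two cannot be ordered. Compound 4 `CCC1=C(O)c2c(oc(-c3ccc(F)c(C)c3)cc2=O)C(CC)(CC)C1=O` carries 4-fluoro-3-methylphenyl in place of 2,4-dimethylphenyl on an aromatic carbon. Fluorine on the aryl ring was seen in compound 2, whose limit gives no number to weigh, while the methyl retained resembles compound 3; a small upward shift at most seems likely. Compound 4 is therefore expected to give about 50 uM, from 20 uM to 120 uM, meaning a 1.2-fold higher number from compound 3 to compound 4 (0.08 log units; within the scatter), which may stay within the scatter.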

Compound 4, concentration for half-maximal effect: 40.5 uM
The estimate for compound 4 lay 1.2-fold (0.09 log units) above the measured number, within the range that was stated.
By their numbers in this assay, from the lowest: compound 1; then compounds 4 and 3 (each within the scatter of the next). At a limit, above all of these: compound 2.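

4-fluoro-3-methylphenyl in place of 2,4-dimethylphenyl gives a step (a 1.0-fold lower number from compound 3 to compound 4 (0.01 log units; within the scatter)), so in this assay an aryl group carrying fluorine can still give a measured number. The 3-methoxyphenyl of compound 1 remains distinct from this group (a 3.0-fold higher number from compound 1 to compound 4 (0.48 log units; beyond the scatter)). The step (an at least 1.3-fold lower number from compound 2 to compound 4 (0.14 log units; that floor lies within the scatter)) cannot be read as an order, since compound 2 stands only at a limit: the limit of > 56.2 uM in this assay, at which 1 of the 4 values shown sits.

The compounds shown leave open whether the methoxy group itself sets compound 1 apart, or whether another substituent at that ring position would do the same. They also leave open how an amine or a carboxylic acid on this aryl ring would read.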